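A few compounds are considered here, and "the series" means these few. Any claim that something is new, unique, unknown or untested is made for them only; others in the source may bear on it.

Compound 1 `COC(/C=C/c1ccccc1)=C1\C(=O)C=C(C)C1=O` was tested in an ADME assay on Vero cells (Chlorocebus sabaeus) for cytotoxicity, read by neutral red uptake (on this read-out lower numbers stand for stronger inhibition and higher numbers for weaker inhibition), and compound 1 gives 4.9 ug/mL. Compound 2 `COC(/C=C/c1ccc(O)cc1)=C1\C(=O)C=C(C)C1=O` carries a hydroxy in place of hydrogen on an aromatic carbon; in this assay compound 2 gives 3.7 ug/mL, which is a 1.3-fold lower number from compound 1 to compound 2 (0.12 log units; within the scatter). Going by the values given here, compound 1 therefore stands highest of the two numbers, with compound 2 as its only neighbour within the scatter. Compound 3 `COC(/C=C/c1ccco1)=C1\C(=O)C=C(C)C1=O` differs from compound 1 differently: furan-2-yl in place of phenyl on a double-bonded chain carbon bound to a double-bonded chain carbon. Among the compounds with values here, no measured step touches the aromatic ring itself, so the one known step offers no guide, and a step staying within the scatter is expected. Compound 3 is estimated at 4.9 ug/mL, between 2.4 ug/mL and 10 ug/mL. That amounts to an expected no change at the digits printed from compound 1 to compound 3 (within the scatter).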

Compound 3, half-maximal inhibitory concentration: 3.3 ug/mL
For compound 3 the middle estimate is 1.5-fold (0.17 log units) above the measured one; measured number inside the range.
By their numbers in this assay, from the lowest: compounds 3, 2 and 1 (each within the scatter of the next).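

Replacing the whole aromatic ring, not just adding a group to it, gives a 1.5-fold lower number from compound 1 to compound 3 (0.17 log units; within the scatter) in this assay and so stays within the scatter. On this double-bonded chain carbon, a five-membered aromatic ring with one oxygen therefore stands in for a six-membered ring of carbon only without a clear shift in the number. No measured evidence bears on this result.

From the compounds shown here alone, whether a saturated ring such as cyclohexyl, or a phenyl carrying an amine or a carboxylic acid, would move the number beyond the scatter stays open.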